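The compounds below may be only part of what the source reports. "The series", "measured", "known", "first", "only" and "open" are said of these compounds alone.

The measured compounds:

- compound 1, `O=C(NNC(=O)C1CC1c1ccc(OC(F)(F)F)cc1)c1ccncc1`, which in a functional assay on A549 cells (Homo sapiens) for inhibition, read by MTT assay, with a stated time of 72 h (a lower number here means a stronger inhibitor, a higher number a weaker inhibitor), gives 56000 nM
- compound 2, `CCOc1ccc(C2CC2C(=O)NNC(=O)c2ccncc2)cc1`, which in this assay gives 43000 nM
- compound 3, `COc1ccc(C2CC2C(=O)NNc2nncc3ccccc23)cc1`, which in this assay gives 96000 nM

Compound 3 has the highest of the three numbers in this assay. Its nearest neighbour is compound 1, a gap within the scatter; its furthest is compound 2, a gap that lies beyond the scatter.

The step to compound 4, `CCOc1ccc(C2CC2C(=O)NNc2nncc3ccccc23)cc1`, is methyl in place of hydrogen on a saturated chain carbon bound to an oxygen on an aromatic ring; cut one bond further out, it reads methoxy to ethoxy. Going by the values given here, only one measured step bears on it: a 1.3-fold lower number from compound 1 to compound 2 (0.11 log units; within the scatter), a change of the group on the aromatic oxygen in a different core, which stayed within the scatter. Among the compounds with values here, no measured pair shows methoxy against ethoxy directly.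

On that basis the step is expected to be small in this assay. Compound 4 is estimated at 80000 nM, with a range from 40000 nM to 160000 nM. The expected step is therefore a 1.2-fold lower number from compound 3 to compound 4 (0.08 log units; within the scatter), not beyond the scatter.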

Compound 4, half-maximal inhibitory concentration: > 100000 nM
Compound 4 ended at the assay's limit; the forecaster's own chance of this, stated with the estimate: 10%; middle value at least 1.2-fold (0.09 log units) away from the limit.
By their numbers in this assay, from the lowest: compounds 2, 1 and 3 (each within the scatter of the next, the first and the last beyond it). At a limit, above all of these: compound 4.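

Going by these compounds alone, this pair gives the first direct reading of methoxy to ethoxy within a single core, with methyl in place of hydrogen on a saturated chain carbon bound to an oxygen on an aromatic ring. The earlier step from compound 1 to compound 2 changed the group on the aromatic oxygen only in a different core, and from trifluoromethyl rather than from methyl. In this assay compound 4 gives a limit and not a number: the limit of > 100000 nM in this assay, at which 1 of the 4 values shown sits. On these data alone, the step reads an at least 1.0-fold higher number from compound 3 to compound 4 (0.01 log units; that floor lies within the scatter), so on this core the added methyl gives no sign of a lower number, yet that floor does not set the two compounds apart and the true size of the step stays unknown.

As far as these compounds go, it remains open whether a longer chain on the aromatic oxygen, or an amine or a hydroxyl group in place of the whole ethoxy group, would bring this core to a clearly lower number. From the compounds shown here alone, it also remains open whether methoxy to ethoxy would read the same way in the core of compound 1.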